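The source may report more compounds than this note shows. Statements on the series, on what has been measured and on what is new or still open speak of the compounds shown alone.

Compound 1 `Fc1cc(Cl)ccc1-c1ccc(Cn2nnc3ccccc32)cn1` gives 50 nM in a functional assay on cells for positive allosteric modulation of metabotropic glutamate receptor 2 (Homo sapiens), read by fluorescence and calcium flux, with a stated time of 30 min; on this read-out lower numbers stand for an effect already at smaller amounts and higher numbers for an effect only at larger amounts of compound. Compound 2 `Fc1ccc2c(c1)nnn2Cc1ccc(-c2ccc(Cl)cc2F)nc1` differs from it by fluoro in place of hydrogen on an aromatic carbon; in this assay compound 2 gives 68 nM, a step of a 1.4-fold higher number from compound 1 to compound 2 (0.13 log units; within the scatter). Compound 3 `Clc1ccc(Cn2nnc3c(Br)cccc32)cc1` stands on another core, and the difference between the two cores is not broken down here; in this assay compound 3 gives 17 nM. Compound 4 `Fc1cc(Cn2nnc3c(Br)cccc32)ccc1Cl` is not yet measured. It differs from compound 3 by fluoro in place of hydrogen on an aromatic carbon. This is the same kind of change as the one made twice among these compounds, yet the place differs: earlier it lay on a ring that is part of a fused or bridged system of two rings, meta to a fused ring and para to a fused ring, whereas here it is ortho to a chloro group and meta to a large group. Because the earlier step was a 1.4-fold higher number from compound 1 to compound 2 (0.13 log units; within the scatter), compound 4 is expected to stay near compound 3. The expected step is a 1.2-fold higher number from compound 3 to compound 4 (0.07 log units; within the scatter). Compound 4 is estimated at 20 nM in this assay, between 8 nM and 50 nM.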

Compound 4, half-maximal effective concentration: 18 nM
Beside the measured number, compound 4's estimate is 1.1-fold (0.05 log units) above it; the range from low to high includes it.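

In this assay, fluoro in place of hydrogen on an aromatic carbon gives a 1.1-fold higher number from compound 3 to compound 4 (0.02 log units; within the scatter). Set beside the earlier step, the change carries from one core to the other with no difference that stands out from the scatter: the same change on two cores in this assay, a 1.4-fold higher number (0.13 log units; within the scatter) from compound 1 to compound 2 and a 1.1-fold higher number (0.02 log units; within the scatter) from compound 3 to compound 4, 1.3-fold (0.11 log units) apart, within the scatter of two such steps. Among the compounds shown here, this rests on only two pairs, with the fluoro at a different place in each, so it gives no rule for other cores or other places on these rings.

The compounds shown leave open whether a methoxy group, a trifluoromethyl group or an amine in the same place would also leave the number within the scatter on both cores. They also leave open whether a second fluoro would do so.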